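From a urea back to a plain benzamide

This account rests on a few compounds, and the source may have more. Where it says the series, first, only, none or still open, it means among the compounds named here.

Within the data shown here, compound 3 `COc1cc(-c2nn(-c3cccc(NC(=O)Nc4ccc(Cl)c(C(F)(F)F)c4)c3)cc2-c2ccncc2)ccc1Cl` carries a urea, and in a functional assay on 786-0 cells (Homo sapiens) for inhibition, read by sulforhodamine B assay, with a stated time of 48 h (on this read-out higher numbers stand for weaker inhibition of growth and lower numbers for stronger inhibition of growth), compound 3 gives 8020 nM, the only numeric value among the three measured compounds. Compound 1 `COc1cc(-c2nn(-c3cccc(NC(=O)c4ccc(Cl)c(C(F)(F)F)c4)c3)cc2-c2ccncc2)ccc1Cl` is the matching amide; in this assay compound 1 reaches only the limit > 32500 nM. Compound 2 `COc1cc(-c2nn(-c3cccc(NC(=O)c4cccc(C(F)(F)F)c4)c3)cc2-c2ccncc2)ccc1Cl` drops the chloro; in this assay compound 2 also reaches only the limit > 50000 nM. The steps of an at least 4.0-fold lower number from compound 1 to compound 3 (0.60 log units; beyond the scatter) and an at least 6.2-fold lower number from compound 2 to compound 3 (0.79 log units; beyond the scatter) both run toward the urea. Compound 4 `COc1cc(-c2nn(-c3cccc(NC(=O)c4ccccc4)c3)cc2-c2ccncc2)ccc1Cl` goes the other way: phenyl in place of (4-chloro-3-(trifluoromethyl)phenyl)amino on a carbonyl carbon. Reversing those two steps, and removing the remaining substituents as well, an increase beyond the scatter is expected, a 6.2-fold higher number from compound 3 to compound 4 (0.79 log units; beyond the scatter), probably ending at a limit. Compound 4 is therefore estimated at 50000 nM, between 15000 nM and 120000 nM.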

Compound 4, concentration for total growth inhibition: > 100000 nM
Compound 4: only a limit was reported; the forecaster's own chance of this, stated with the estimate: 60%; at least 2.0-fold (0.30 log units) between middle value and limit.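

In this assay, putting phenyl in place of (4-chloro-3-(trifluoromethyl)phenyl)amino on the carbonyl carbon gives an at least 12-fold higher number from compound 3 to compound 4 (1.09 log units; beyond the scatter), so this change carries a large loss of growth inhibition. Compound 4 is reported only as a limit: the limit of > 100000 nM in this assay, at which 1 of the 4 values shown sits. The steps among compound 1, compound 2 and compound 4 cannot be read, as all three values are limits.

Going by these compounds, the change to compound 4 removes the urea nitrogen and both ring substituents together, so their separate shares remain open. A plain phenylamino group on the carbonyl carbon would separate them.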